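A few compounds are considered here, and "the series" means these few. Any claim that something is new, unique, unknown or untested is made for them only; others in the source may bear on it.

Measured compounds in this study:

compound 1 `O=C(O)[C@@H]1CCCN1C(=O)CN(c1nc(Cl)nc2[nH]cnc12)C1CC1` — 26%
compound 2 `CC(C)[C@H](NC(=O)CN(c1nc(Cl)nc2[nH]cnc12)C1CC1)C(=O)OCc1ccccc1` — 51.3%
compound 3 `O=C(O)CNC(=O)CN(c1nc(Cl)nc2[nH]cnc12)C1CC1` — 32.3%

These three compounds share one core and were tested in a functional assay on the whole organism (Tail, strain ICR) with Mus musculus as the target, in the tail flick test, with a stated time of 90 min, at a dose of 25 umol/kg by the oral route; on this read-out lower numbers stand for a weaker effect and higher numbers for a stronger effect at the one dose given. Compound 3 stands second of the three numbers. For the measured compounds named here, its nearest neighbour is compound 1, and the one measured step, a number 6.3 percentage points higher from compound 1 to compound 3 (within the scatter), stays within the scatter. Compound 2 lies furthest away, with a number that is higher beyond the scatter.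

Compound 4 `CC(C)[C@H](NC(=O)CN(c1nc(Cl)nc2[nH]cnc12)C1CC1)C(=O)O` has not yet been measured. Its difference from compound 3 is isopropyl in place of hydrogen on a saturated chain carbon bound to an amide-type nitrogen and a carbonyl carbon. Going by the values given here, no measured step shows this exact change: the only measured step, from compound 1 to compound 3, concerns a different part of the molecule, and compound 2, which carries the same isopropyl group but as a benzyl ester rather than a free acid, has no step to compound 4 in hand. The expectation for compound 4 in this assay therefore rests mainly on compound 3 at 32.3%, with compound 2 at 51.3% hinting at a possible rise. For compound 4 a step of a number 7.7 percentage points higher from compound 3 to compound 4 (within the scatter) is expected, and the estimated value is 40%, between 22% and 58%.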

Compound 4, a percentage reported as activity, at one dose (the size of the read-out at that dose, not a potency): 30.3%
Beside the measured number, compound 4's estimate is 9.7 percentage points above it; the measured number falls inside the stated range.
By their numbers in this assay, from the lowest: compounds 1, 4 and 3 (each within the scatter of the next); then compound 2.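

In this assay, isopropyl in place of hydrogen on the saturated chain carbon bound to an amide-type nitrogen and a carbonyl carbon leaves the read-out essentially unchanged, with a number 2 percentage points lower from compound 3 to compound 4 (within the scatter), and the comparison with the proline-type compound also gives no clear change, with a number 4.3 percentage points higher from compound 1 to compound 4 (within the scatter). The free acid and its benzyl ester do separate: with hydrogen in place of benzyl on an oxygen next to a carbonyl group, there is a number 21 percentage points lower from compound 2 to compound 4 (beyond the scatter), so compound 2's higher number cannot be credited to isopropyl alone. Nothing available explains this difference.

On these data alone, whether a benzyl ester on compound 3 would go with a similar rise remains open, as does the outcome with a methyl or ethyl ester. The effect of a longer chain or a phenyl group in place of isopropyl on that carbon is also unresolved.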